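From a Limit Toward a Number: Adding Ethoxycarbonyl

The compounds below may be only part of what the source reports. "The series", "measured", "known", "first", "only" and "open" are said of these compounds alone.

Compound 1 `O=C(Nc1ccccc1F)N1c2ccnn2CC1c1ccccc1`: > 1000 nM
Compound 2 `O=C(Nc1cccc2ccccc12)N1c2ccnn2CC1c1ccccc1`: > 1000 nM

In a functional assay on cells (Neutrophil, Homo sapiens) for inhibition, with a stated time of 10 min (on this read-out lower numbers stand for stronger inhibition and higher numbers for weaker inhibition), compound 2 stands at > 1000 nM, which is a limit and not a number. Neither measured compound gives a number, and the picture so far is the limit of > 1000 nM in this assay, at which 2 of the 2 values shown sit. Compound 3 `CCOC(=O)c1cnn2c1N(C(=O)Nc1cccc3ccccc13)C(c1ccccc1)C2` carries ethoxycarbonyl in place of hydrogen on an aromatic carbon of the five-membered aromatic ring with 2 nitrogen (ethoxycarbonyl in place of hydrogen on an aromatic carbon). Among the compounds with values here, no measured pair shows what such a change does in this assay, so the expectation is loose. The expected change toward stronger inhibition is an at least 5.0-fold lower number from compound 2 to compound 3 (0.69 log units; beyond the scatter). For compound 3 the estimated value is 200 nM, with an expected range of 5 nM to 2000 nM.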

Compound 3, half-maximal inhibitory concentration: 206 nM
Compound 3: middle estimate off by 1.0-fold (0.01 log units), on the low side; the range from low to high includes it.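

In this assay ethoxycarbonyl in place of hydrogen on an aromatic carbon gives an at least 4.8-fold lower number from compound 2 to compound 3 (0.68 log units; beyond the scatter) and so shows that this position of the shared core can change the read-out. Only compound 3 gives a number, so the step has a bound and not a full size; the others remain at a limit: the limit of > 1000 nM in this assay, at which 2 of the 3 values shown sit.

On these data alone, it remains open whether a carboxylic acid, a primary amide or a nitrile on this carbon would give a similar number. As far as these compounds go, it is also open whether ethoxycarbonyl would produce a similar step on compound 1.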